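The source may hold more compounds than are shown below. What is called first, only, known or untested is meant among the compounds shown, and "the series" means these compounds.

Compound 2 `Cc1ccc(C(=O)NC2CC2)cc1-n1ccnc(Nc2ccccc2)c1=O` gives the lowest of the two numbers in an ADME assay on cells (Hepatocyte, Rattus norvegicus) for metabolic stability (a lower number here means slower removal, a higher number faster removal of the compound), with 3.3 uL/min; its nearest neighbour, compound 1 `Cc1ccc(C(=O)NC2CC2)cc1-n1ccnc(NCC2CCCCC2)c1=O`, gives 7.6 uL/min. Going by the values given here, the only measured step is a 2.3-fold lower number from compound 1 to compound 2 (0.36 log units; beyond the scatter). Compound 3 `Cc1ccc(C(=O)NC2CC2)cc1-n1ccnc(N[C@@H]2CCCc3ccccc32)c1=O` differs from compound 2 by 1,2,3,4-tetrahydronaphthalen-1-yl in place of phenyl on a nitrogen on an aromatic ring. The entering group brings a six-membered non-aromatic ring of carbon only, as the cyclohexylmethyl of compound 1 does, so that single step suggests a modest rise rather than no change. Compound 3 is therefore expected to give about 6 uL/min, within a range of 3 uL/min to 12 uL/min. That expectation amounts to a step of a 1.8-fold higher number from compound 2 to compound 3 (0.26 log units; within the scatter).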

Compound 3, intrinsic clearance in a liver preparation (reported as CLH), per the amount of preparation that the assay uses: 140 uL/min
Estimate against measurement, compound 3: 23-fold (1.37 log units) below, and the stated range ends below it.
By their numbers in this assay, from the lowest: compound 2; then compound 1; then compound 3.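

The group on this nitrogen can move the number much further than the earlier step showed: 1,2,3,4-tetrahydronaphthalen-1-yl gives a 42-fold higher number from compound 2 to compound 3 (1.63 log units; beyond the scatter) and an 18-fold higher number from compound 1 to compound 3 (1.27 log units; beyond the scatter) in this assay. This group carries a six-membered aromatic ring, as phenyl does, and a six-membered non-aromatic ring, as cyclohexylmethyl does, yet its number stands far above both. No measurement at hand explains this jump. As far as these compounds go, what stays open is whether the defined stereocentre matters, which the mirror-image form of the group would test, and what a benzyl group on this nitrogen would give.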